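This account rests on a few compounds, and the source may have more. Where it says the series, first, only, none or still open, it means among the compounds named here.

Compound 1 `O=C(CSc1ccc(Cl)cc1)Nc1ccc2nc(NC(=O)c3ccc4ccccc4c3)sc2c1`: 4040 nM
Compound 2 `O=C(CSc1cccc(O)c1)Nc1ccc2nc(NC(=O)c3ccccc3)sc2c1`: 41000 nM
Compound 3 `Cc1ccc(S(=O)(=O)Nc2nc(C)c(NC(=O)Nc3ccc(Cl)cc3)s2)cc1`: 47400 nM

In a functional assay on HCT-116 cells (Homo sapiens) for antiproliferative activity, read by MTT assay, with a stated time of 72 h (on this read-out lower numbers stand for stronger inhibition and higher numbers for weaker inhibition), compound 1 gives 4040 nM, the lowest of the three numbers shown. Compound 2 gives 41000 nM and compound 3 gives 47400 nM, and both of these lie beyond the scatter from compound 1, so compound 1 stands apart as the lowest number of the set.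

Compound 4 `Cc1ccc(C(=O)Nc2nc3ccc(NC(=O)CSc4ccc(Cl)cc4)cc3s2)cc1` has not yet been measured in this assay. It differs from compound 1 in one place: 4-methylphenyl in place of naphthalen-2-yl on a carbonyl carbon. Going by the values given here, no pair of measured compounds shares this exact change, so there is no measured step to lean on. Compound 2, which differs from compound 1 in more than one place, gives a far higher number than compound 1, but that comparison cannot be tied to a single change. On this thin basis the step of a 2.2-fold higher number from compound 1 to compound 4 (0.35 log units; beyond the scatter) is expected to be a modest rise, possibly beyond the scatter, rather than a fall. Compound 4 is therefore estimated at 9000 nM, with a range from 2500 nM to 30000 nM.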

Compound 4, half-maximal inhibitory concentration: 2120 nM
Compound 4: the middle estimate sits 4.2-fold (0.63 log units) above what was measured; the whole stated range lies above it.
By their numbers in this assay, from the lowest: compounds 4 and 1 (each within the scatter of the next); then compounds 2 and 3 (each within the scatter of the next).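

In this assay, putting 4-methylphenyl in place of naphthalen-2-yl on a carbonyl carbon gives a 1.9-fold lower number from compound 1 to compound 4 (0.28 log units; within the scatter), the first single-place step available for this position. The second aromatic ring of naphthalen-2-yl is therefore not needed to keep the number at this level, since a group with one six-membered aromatic ring of carbon only and fewer heavy atoms reads the same within the scatter. No measurement at hand explains why these two groups read alike.

The compounds shown leave open whether an amine or a carboxylic acid on the phenyl ring, or a saturated cyclohexyl ring, would hold the number at this position. They also leave open what the other end of the molecule contributes, as compound 2 differs from compound 1 in more than one place.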